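The source may hold more compounds than are shown below. What is called first, only, known or untested is meant among the compounds shown, and "the series" means these compounds.

Measured compounds:
- compound 1 `Cc1nn(C)c2nc(C(C)C)c(/C=C/[C@@H](O)C[C@@H](O)CC(=O)O)c(-c3ccc(F)cc3)c12`: 48.1%
- compound 2 `Cc1nn(-c2ccccc2)c2nc(C(C)C)c(/C=C/[C@@H](O)C[C@@H](O)CC(=O)O)c(-c3ccc(F)cc3)c12`: 19.9%
- compound 3 `COc1ccc(-n2nc(C)c3c(-c4ccc(F)cc4)c(/C=C/[C@@H](O)C[C@@H](O)CC(=O)O)c(C(C)C)nc32)cc1`: 48.7%

In an in vivo functional assay on the whole organism for inhibition of 3-hydroxy-3-methylglutaryl-coenzyme A reductase (Rattus norvegicus), at a dose of 2 mg/kg by the oral route (a higher number here means a stronger effect of the compound at the dose given, a lower number a weaker effect), compound 1 stands second highest of the three numbers. The step of a number 0.6 percentage points higher from compound 1 to compound 3 (within the scatter) is within the scatter, while the step of a number 28.2 percentage points lower from compound 1 to compound 2 (beyond the scatter) is beyond it; compound 2 and compound 3 are separated by a number 28.8 percentage points higher from compound 2 to compound 3 (beyond the scatter).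

Compound 4 `CC(C)c1nc2c(c(C3CC3)nn2C)c(-c2ccc(F)cc2)c1/C=C/[C@@H](O)C[C@@H](O)CC(=O)O` differs from compound 1 in one place: cyclopropyl in place of methyl on an aromatic carbon. Within the data shown here, none of the measured steps touches this position; the three measured compounds all carry a methyl on that aromatic carbon and vary only the substituent on the aromatic nitrogen. Among the measured compounds shown here, the only step of a comparable kind, a larger carbon group in place of a small one, is a number 28.2 percentage points lower from compound 1 to compound 2 (beyond the scatter), but it sits at a different place and one of its partners, compound 3, shows that a larger group there need not cost activity. The step from compound 1 to compound 4 is therefore expected to be small, a number 6.1 percentage points lower from compound 1 to compound 4 (within the scatter), with a slight downward lean; compound 4 is estimated at 42%, with a range from 25% to 58%.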

Compound 4, a percentage reported as inhibition, in the whole organism at one dose (the size of the read-out at that dose, not a potency): 71.3%
The estimate for compound 4 lay 29.3 percentage points below the measured number, and the stated range ends below it.
By their numbers in this assay, from the lowest: compound 2; then compounds 1 and 3 (each within the scatter of the next); then compound 4.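

The aromatic carbon that carries methyl in compounds 1, 2 and 3 responds to change in this assay: cyclopropyl in place of methyl gives a number 23.2 percentage points higher from compound 1 to compound 4 (beyond the scatter) and so shows that this position accepts a larger carbon group with a higher read-out at this dose. The earlier steps shown here from compound 1 all sit on the aromatic nitrogen and read a number 28.2 percentage points lower from compound 1 to compound 2 (beyond the scatter) and a number 0.6 percentage points higher from compound 1 to compound 3 (within the scatter) so neither of them lifts the number beyond the scatter. No measurement at hand bears on why the number rises here.

On these data alone, whether the gain belongs to cyclopropyl itself or extends to other groups on this carbon stays open, and ethyl, cyclobutyl or an amine there would test that. Also open, as far as these compounds go, is how cyclopropyl on this carbon behaves alongside phenyl or 4-methoxyphenyl on the aromatic nitrogen.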